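The source may report more compounds than this note shows. Statements on the series, on what has been measured and on what is new or still open speak of the compounds shown alone.

Measured in an ADME assay on microsomes from liver (Mus musculus) for metabolic stability; a higher number here means that the compound lasts longer, a lower number that the compound disappears faster:
- Compound 1 `CCn1ncc2c(F)cc(-c3ccc(C(CC)(CC)c4nnc[nH]4)c(=O)[nH]3)cc21`: > 3 h, a limit of the assay
- Compound 2 `CCn1ncc2c(F)cc(-c3ccc(C(CC)(CC)c4nnc(C)[nH]4)c(=O)[nH]3)cc21`: > 3 h, a limit of the assay
- Compound 3 `CC(C)C(c1ccc(-c2ccc3cccc(F)c3c2)[nH]c1=O)N1CCCCC1=O`: 0.0967 h

Among the measured compounds shown here, compound 3 holds the only true number among the three. Compound 1 and compound 2 sit at the limit of > 3 h in this assay, at which 2 of the 3 values shown sit.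

The next compound, compound 4 `CC(C)C(c1ncc[nH]1)c1ccc(-c2ccc3cccc(F)c3c2)[nH]c1=O`, is reached from compound 3 by one change: 1H-imidazol-2-yl in place of 2-oxopiperidin-1-yl on a saturated chain carbon bound to an aromatic carbon and a saturated chain carbon. In words, 1H-imidazol-2-yl takes the place of 2-oxopiperidin-1-yl on a saturated chain carbon bound to an aromatic carbon and a saturated chain carbon.

For the measured compounds named here, the only measured step is a step that the two limits leave unreadable from compound 1 to compound 2. That step is a methyl in place of hydrogen on an aromatic carbon, a different change, and it has no readable size. It therefore offers no guide to this exchange, and no direction can be argued from the data. The expectation is of no step beyond the usual scatter, estimated as a 1.6-fold higher number from compound 3 to compound 4 (0.19 log units; within the scatter).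

For compound 4 the estimated half-life is 0.15 h, with an expected range from 0.05 h to 0.6 h.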

Compound 4, half-life: < 0.0667 h
Compound 4 ended at the assay's limit; the forecaster's own chance of this, stated with the estimate: 5%; middle value at least 2.2-fold (0.35 log units) from the limit.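

Among the compounds shown here, the step at this position is the first that can be read at all, and only as a floor: in this assay the exchange of 2-oxopiperidin-1-yl for 1H-imidazol-2-yl gives an at least 1.4-fold lower number from compound 3 to compound 4 (0.16 log units; that floor lies within the scatter). Compound 4 ends at a limit of the assay and not at a number: the limit of < 0.0667 h in this assay, at which 1 of the 4 values shown sits. So 1H-imidazol-2-yl on this saturated chain carbon brings no gain in half-life over 2-oxopiperidin-1-yl, and the true size of the step may be larger than its floor.

As far as these compounds go, how far compound 4 lies past its limit stays open, so the step may be within the scatter or well beyond it. From the compounds shown here alone, whether an amine or a carboxylic acid on this same carbon would give a longer half-life also stays open.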